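Aryl sulfonamide amides: from compound 1 to compound 4

The compounds below may be only part of what the source reports. "The series", "measured", "known", "first", "only" and "open" are said of these compounds alone.

Compound 1 `O=C(Nc1ccc(S(=O)(=O)Nc2ccccc2)cc1)c1cc(F)c(Cl)cc1F` gives 37% in a functional assay on HEK293 cells for agonist activity at probable G-protein coupled receptor 27 (Homo sapiens), read by a luciferase reporter and beta-arrestin recruitment, with a stated time of 10 min; a higher number here means a larger maximal response, a lower number a smaller maximal response. Compound 3 `O=C(Nc1ccc(S(=O)(=O)Nc2cccc(Cl)c2)cc1)c1ccc(Cl)cc1Cl` gives 40% in this assay; compound 1 stands at the low end of these two numbers, yet the gap lies within the usual scatter, so the pair reads as a single level. Compound 2 `O=C(NS(=O)(=O)c1ccc(NC(=O)c2ccc(Cl)cc2Cl)cc1)c1ccccc1` gives "not determined" (no result reported) in this assay. Within the data shown here, compound 4 `O=C(Nc1ccc(S(=O)(=O)Nc2ccccc2)cc1)c1ccc(Cl)nc1F` carries the change (6-chloro-2-fluoropyridin-3-yl in place of 4-chloro-2,5-difluorophenyl on a carbonyl carbon); no measured pair in the set shows this step. With a single level shown and no step to lean on, no change beyond the scatter is expected in either direction, and the expected step is a number 1 percentage points higher from compound 1 to compound 4 (within the scatter). Compound 4 is therefore estimated at 38% in this assay, with a range from 20% to 60%.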

Compound 4, largest response reached (Emax), in percent of the reference or control that the assay uses: 78%
Estimate against measurement, compound 4: 40 percentage points below, and the stated range ends below it.
By their numbers in this assay, from the lowest: compounds 1 and 3 (each within the scatter of the next); then compound 4.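

At the carbonyl carbon, 6-chloro-2-fluoropyridin-3-yl in place of 4-chloro-2,5-difluorophenyl gives a number 41 percentage points higher from compound 1 to compound 4 (beyond the scatter) in this assay, a large step. This position can therefore move the maximal response well away from the single level that the earlier numbers showed. No measured evidence bears on the reason for this step.

Going by these compounds, the exchange adds a ring nitrogen and removes one fluorine, so which of these changes carries the step remains open. Also open, on these data alone, is whether an amine or a methoxy group in place of the chlorine keeps the response.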